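Working notes on an amide substituent swap

The compounds below may be only part of what the source reports. "The series", "measured", "known", "first", "only" and "open" are said of these compounds alone.

Two members of this series have been run in a functional assay on NIH3T3 cells (Mus musculus); on this read-out higher numbers stand for an effect only at larger amounts of compound and lower numbers for an effect already at smaller amounts. Compound 1, with the structure `COC(=O)[C@H](CCSC)NC(=O)c1ccc(NCc2cncn2Cc2ccc(C)cc2)cc1-c1ccccc1`, gives only a limit in this assay: its value is > 10 uM. Compound 2, with the structure `N#Cc1ccc(Cn2cncc2CNc2ccc(C(=O)Nc3cccc([N+](=O)[O-])c3)c(-c3ccccc3)c2)cc1`, likewise gives only a limit in this assay, > 10 uM. Going by the values given here, compound 2 therefore stands at the same place as the one other value shown, namely (the limit of > 10 uM in this assay, at which 2 of the 2 values shown sit), and no number separates the two; nothing more can be said of their order.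

The next compound, compound 3, has the structure `CSCC[C@H](NC(=O)c1ccc(NCc2cncn2Cc2ccc(C#N)cc2)cc1-c1ccccc1)C(=O)O` and has not yet been measured in this assay. It differs from compound 2 at the amide-type nitrogen whose other neighbour is the carbonyl carbon: 1-carboxy-3-(methylsulfanyl)propyl in place of 3-nitrophenyl on an amide-type nitrogen, that is, 1-carboxy-3-(methylsulfanyl)propyl in place of 3-nitrophenyl.

No measured pair in the series spans a change of this kind, so the step from compound 2 to compound 3 cannot be anchored to anything shown. With both measured compounds sitting at the limit, the expectation for compound 3 is an outcome near that limit, the step that the limit leaves unreadable from compound 2 to compound 3 being expected to stay within the scatter. The estimate for compound 3 in this assay is 15 uM, in a range from 4 uM to 60 uM.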

Compound 3, concentration for half-maximal effect: > 10 uM
Compound 3 ended at the assay's limit (the forecaster's own chance of this, stated with the estimate: 70%); the middle value does not contradict the limit.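

In this assay compound 3 gives > 10 uM, a limit of the assay and not a number, and with compound 2 also at a limit, no step can be read between compound 2 and compound 3. The compounds shown leave open whether any amide substituent on the shared core gives a value inside the assay's range.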